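Furan amide for oxane amide: expected solubility

A few compounds are considered here, and "the series" means these few. Any claim that something is new, unique, unknown or untested is made for them only; others in the source may bear on it.

Measured so far in a physicochemical assay for solubility, read by mass spectrometry, in phosphate buffer, with a stated time of 24 h, at pH 3 (on this read-out higher numbers stand for higher solubility and lower numbers for lower solubility), are these compounds:
- compound 1 `O=C(Nc1ccc(C(F)(F)F)cc1)NC1CCN(C(=O)C2CCCOC2)CC1` (25 ug/mL)
- compound 2 `O=C(Nc1ccc(OC(F)(F)F)cc1)NC1CCN(C(=O)C2CCOCC2)CC1` (1300 ug/mL)
- compound 3 `Cc1occc1C(=O)N1CCC(NC(=O)Nc2ccc(OC(F)(F)F)cc2)CC1` (7.7 ug/mL)

Compound 1 holds the middle of the three numbers, with both gaps beyond the scatter. Compound 4 `Cc1ccoc1C(=O)N1CCC(NC(=O)Nc2ccc(C(F)(F)F)cc2)CC1` has 3-methylfuran-2-yl in place of oxan-3-yl on a carbonyl carbon. Among the measured compounds shown here, the one measured step that bears on this is a 170-fold lower number from compound 2 to compound 3 (2.23 log units; beyond the scatter) for a related swap, and it is large. The starting points differ, as compound 2 gives 1300 ug/mL and compound 1 gives 25 ug/mL, so a drop of that full size is not expected. A moderate fall is expected in this assay as the estimated step (a 4.2-fold lower number from compound 1 to compound 4 (0.62 log units; beyond the scatter)). Compound 4 is estimated at 6 ug/mL (1.5 ug/mL to 25 ug/mL).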

Compound 4, solubility: 1.8 ug/mL
Estimate against measurement, compound 4: 3.3-fold (0.52 log units) above; measured number inside the range.
By their numbers in this assay, from the lowest: compound 4; then compound 3; then compound 1; then compound 2.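

In this assay the swap on the carbonyl carbon again gives a large fall, a 14-fold lower number from compound 1 to compound 4 (1.14 log units; beyond the scatter), and this time from a much lower starting number than that of compound 2. Together with a 170-fold lower number from compound 2 to compound 3 (2.23 log units; beyond the scatter), this makes two pairs in which a methylfuran in place of an oxane lowers the number, and no pair shown goes against this. Nothing shown bears on the reason for the fall.

Still open, going by these compounds, is how oxan-3-yl and oxan-4-yl compare with the rest of the molecule held constant. Also open, on these data alone, is how a carbonyl substituent carrying an amine or a carboxylic acid would read at this position.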